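The source may hold more compounds than are shown below. What is called first, only, known or untested is meant among the compounds shown, and "the series" means these compounds.

Measured compounds:
- compound 1 `CCCCCCCCCCCC(=O)Nc1nnc(S[C@@H]2O[C@H](CO)[C@H](O)[C@H](O)[C@H]2O)s1` — "not active" (no number reported)
- compound 2 `CCCCCCCC(=O)Nc1nnc(S[C@@H]2O[C@H](CO)[C@H](O)[C@H](O)[C@H]2O)s1` — 60100 nM
- compound 3 `CCCCCCCCCCCCCCCCCC(=O)Nc1nnc(S[C@@H]2O[C@H](CO)[C@H](O)[C@H](O)[C@H]2O)s1` — "not active" (no number reported)

Series of acylated thiadiazole glycosides differing only in the length of the saturated acyl chain. In an ADME assay on CHO-K1 cells (Cricetulus griseus) for cytotoxicity, read by MTT assay, with a stated time of 24 h (a higher number here means a weaker inhibitor, a lower number a stronger inhibitor), compound 2 gives 60100 nM. Compound 1 is reported as "not active" (no number reported), with no number. Compound 3 likewise stands at "not active" (no number reported), so it has no single value to rank against compound 2; the only thing that can be said is that compound 2 returned a number and compound 3 did not.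

The next compound, compound 4 `CCCCCCCCCCCCCC(=O)Nc1nnc(S[C@@H]2O[C@H](CO)[C@H](O)[C@H](O)[C@H]2O)s1`, differs from compound 3 by hydrogen in place of butyl on a saturated chain carbon, ten or more bonds along the chain from a carbonyl carbon. The resulting chain sits between those of compound 1 and compound 3, both of which gave no number. Among the measured compounds shown here, no measured step exists for this change, and with both neighbours unnumbered the expected size of the step in this assay cannot be read from the series; the most likely outcome is again no number, or a value in the weak range near compound 2 at best.

Compound 4 is expected to give about 120000 nM in this assay, within 40000 nM to 400000 nM, if a number is returned at all.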

Compound 4, half-maximal inhibitory concentration: "not active" (no number reported)
Compound 4 has no reported number here; no gap can be computed for the estimate.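

In this assay compound 3 gives "not active" (no number reported) and compound 4 gives "not active" (no number reported) so no step can be read from this pair. No evidence on this result is available.

From the compounds shown here alone, how chain length relates to the read-out in this assay stays open, since compound 2 alone carries a number.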